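Ethyl to tert-butyl on the side chain of compound 1

The compounds below may be only part of what the source reports. "The series", "measured", "known", "first", "only" and "open" are said of these compounds alone.

Compound 1, `CC[C@@H](Nc1n[s+]([O-])nc1Nc1cccc(C(=O)N(C)C)c1O)c1ccc(C)o1`: 234 nM in an assay on isolated protein for binding affinity to C-X-C chemokine receptor type 1 (Homo sapiens); on this read-out lower numbers stand for stronger inhibition and higher numbers for weaker inhibition
Compound 2, `CC[C@@H](Nc1n[s+]([O-])nc1Nc1cccc(C(=O)N(C)C)c1O)c1cc(C(C)C)co1`: 61 nM in this assay

Compound 1 gives the highest of the two numbers; its nearest neighbour is compound 2, reached by a 3.8-fold lower number from compound 1 to compound 2 (0.58 log units; beyond the scatter). Compound 3, `Cc1ccc([C@H](Nc2n[s+]([O-])nc2Nc2cccc(C(=O)N(C)C)c2O)C(C)(C)C)o1`, differs from compound 1 by tert-butyl in place of ethyl on a saturated chain carbon bound to an aromatic carbon and a nitrogen on an aromatic ring. Going by the values given here, no measured step touches this part of the molecule; the single step from compound 1 to compound 2 alters a different group and shows only that one change here can move the number modestly. Compound 3 is therefore expected to stay close, with a 1.2-fold lower number from compound 1 to compound 3 (0.07 log units; within the scatter), at an estimated 200 nM, between 60 nM and 700 nM.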

Compound 3, inhibition constant: 38 nM
For compound 3 the middle estimate is 5.3-fold (0.72 log units) above the measured one, and the stated range ends above it.
By their numbers in this assay, from the lowest: compounds 3 and 2 (each within the scatter of the next); then compound 1.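

Going by these compounds alone, the step at this saturated chain carbon is the first to test this part of the molecule, and tert-butyl in place of ethyl gives a 6.2-fold lower number from compound 1 to compound 3 (0.79 log units; beyond the scatter) in this assay. A change here, and not only the replacement of the 5-methylfuran-2-yl group, therefore moves the number beyond the scatter. No available evidence bears on why the number falls.

From the compounds shown here alone, whether isopropyl or cyclopropyl at this carbon would fall closer to ethyl or to tert-butyl remains open. So does whether tert-butyl and 4-isopropylfuran-2-yl would combine in a single compound.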